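The compounds below may be only part of what the source reports. "The series", "measured", "known", "first", "only" and "open" are said of these compounds alone.

Three compounds share one core and differ only in what sits on the aromatic ring of that core. Compound 1 `NC(=O)[C@@H](c1ccccc1)N(C(=O)c1ccccc1)[C@@H]1CCc2c(F)cccc21` gives 120 nM in an assay on HEK293T cells for antagonist activity at transient receptor potential cation channel subfamily M member 8 (Homo sapiens), read by fluorescence and calcium flux, with a stated time of 60 min; on this read-out lower numbers stand for stronger inhibition and higher numbers for weaker inhibition. Compound 2 `NC(=O)[C@@H](c1ccccc1)N(C(=O)c1ccccc1)[C@@H]1CCc2c(F)cc(F)cc21` gives 100 nM in this assay, and compound 3 `NC(=O)[C@@H](c1ccccc1)N(C(=O)c1ccccc1)[C@@H]1CCc2c(F)cc(Cl)cc21` gives 300 nM in this assay. Compound 2 has the lowest of the three numbers; the step of a 1.2-fold lower number from compound 1 to compound 2 (0.08 log units; within the scatter) lies within the scatter, while a 3.0-fold higher number from compound 2 to compound 3 (0.48 log units; beyond the scatter) and a 2.5-fold higher number from compound 1 to compound 3 (0.40 log units; beyond the scatter) lie beyond it, so compound 2 and compound 1 cannot be told apart, and only compound 3 stands clearly apart from compound 2.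

Compound 4 `NC(=O)[C@@H](c1ccccc1)N(C(=O)c1cccnc1)[C@@H]1CCc2c(F)cc(F)cc21` is not yet measured. It differs from compound 2 by pyridin-3-yl in place of phenyl on a carbonyl carbon. Among the measured compounds shown here, none of the measured steps touches this part of the molecule: each of them concerns a substituent on an aromatic carbon of the core, and the benzoyl group is the same in compound 1, compound 2 and compound 3. For the measured compounds named here, no measured step therefore bears on this change, and the data give no direction for it. The step of a 1.5-fold higher number from compound 2 to compound 4 (0.18 log units; within the scatter) is expected to fall within the scatter, although the uncertainty is wider than for a change seen before. In this assay compound 4 is estimated at 150 nM, with a range from 50 nM to 450 nM.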

Compound 4, half-maximal inhibitory concentration: 110 nM
Beside the measured number, compound 4's estimate is 1.4-fold (0.13 log units) above it; the measured number falls inside the stated range.
By their numbers in this assay, from the lowest: compounds 2, 4 and 1 (each within the scatter of the next); then compound 3.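

Among the compounds shown here, the benzoyl group stayed the same across the first three compounds, so this is the first look at a change on that carbonyl carbon. In this assay, pyridin-3-yl in place of phenyl gives a 1.1-fold higher number from compound 2 to compound 4 (0.04 log units; within the scatter), which leaves compound 4 and compound 2 indistinguishable. The place therefore takes a ring with one hetero atom and one hydrogen-bond acceptor, where phenyl has none, without a readable change in the number, though nothing at hand explains this outcome.

This single pair says nothing about how other groups on the carbonyl carbon would read, such as cyclohexyl, methyl or morpholine. It also leaves open whether pyridin-3-yl would read the same way on the cores of compound 1 and compound 3.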